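Epimer at the peroxide ring carbon in a sesquiterpene series

The source may report more compounds than this note shows. Statements on the series, on what has been measured and on what is new or still open speak of the compounds shown alone.

Measured so far:
compound 1 `C=C1CCC[C@H]2[C@](C)(CC[C@]3(C)CC[C@@H]([C@@H](C)C(=O)O)OO3)[C@@H](C)CC[C@]12C` — 860 nM
compound 2 `C=C1CCCC(C)(C)C1CC[C@@]1(C)CC[C@H]([C@@H](C)C(=O)O)OO1` — 3350 nM

Working notes. In a functional assay on T47D cells (Homo sapiens) for inhibition (on this read-out lower numbers stand for stronger inhibition of growth and higher numbers for weaker inhibition of growth), compound 1 gives the lower of the two numbers, and compound 2 sits well beyond the scatter above it. Compound 3 `C=C1CCC[C@H]2[C@](C)(CC[C@]3(C)CC[C@H]([C@@H](C)C(=O)O)OO3)[C@@H](C)CC[C@]12C` is not yet measured. The change from compound 1: the two compounds have the same atoms and bonds and differ only in configuration as drawn: 1 of 7 stereo elements differ; a stereocentre at a saturated ring carbon is drawn S in compound 1 and R in compound 3. Within the data shown here, no step between measured compounds informs this kind of change, so the direction is open; a moderate loss beyond the scatter is expected, as a 2.1-fold higher number from compound 1 to compound 3 (0.32 log units; beyond the scatter). Compound 3 is therefore estimated at 1800 nM, within a range of 400 nM to 8000 nM.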

Compound 3, concentration for 50% growth inhibition: 2000 nM
The estimate for compound 3 lay 1.1-fold (0.05 log units) below the measured number; measured number inside the range.
By their numbers in this assay, from the lowest: compound 1; then compounds 3 and 2 (each within the scatter of the next).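

In this assay, changing only the configuration at this saturated ring carbon from S to R gives a 2.3-fold higher number from compound 1 to compound 3 (0.37 log units; beyond the scatter). Among these compounds, this is the first reading for this position alone, and it shows that the stereocentre registers in growth inhibition, though modestly. The step can be tied to this single stereocentre: the fact that compounds 1 and 3 differ only in the configuration as drawn

Going by these compounds, whether the same inversion moves the number in the core of compound 2 remains open. Also open, on these data alone, is how a methyl ester or an amide in place of the carboxylic acid would read in either configuration.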